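The compounds below may be only part of what the source reports. "The series", "measured", "known", "first", "only" and "open" are said of these compounds alone.

Measured so far:
compound 1 `O=C(CI)NCCCCCCCCNc1ncnc2c1ncn2[C@@H]1O[C@H](COP(=O)(O)OP(=O)(O)OP(=O)(O)O)[C@@H](O)[C@H]1O` 47%
compound 2 `O=C(CI)NCCNc1ncnc2c1ncn2[C@@H]1O[C@H](COP(=O)(O)OP(=O)(O)OP(=O)(O)O)[C@@H](O)[C@H]1O` 0%
compound 3 `O=C(CI)NCCCCCCCNc1ncnc2c1ncn2[C@@H]1O[C@H](COP(=O)(O)OP(=O)(O)OP(=O)(O)O)[C@@H](O)[C@H]1O` 20%

In an assay on isolated protein for inhibition of hexokinase-3 (Rattus norvegicus), with a stated time of 6 h, tested at 10 mM (a lower number here means less inhibition, a higher number more inhibition at the concentration tested (going by the name of the read-out)), compound 3 stands second highest of the three, with compound 2 lower by a number 20 percentage points higher from compound 2 to compound 3 (beyond the scatter) and compound 1 higher by a number 27 percentage points lower from compound 1 to compound 3 (beyond the scatter). The unmeasured compound 4 `O=C(I)NCC(=O)NCCCCCCNc1ncnc2c1ncn2[C@@H]1O[C@H](COP(=O)(O)OP(=O)(O)OP(=O)(O)O)[C@@H](O)[C@H]1O` differs from compound 3 by a group of 8 heavy atoms (3 carbon, 2 nitrogen, 2 oxygen, 1 iodine; no ring) in place of a group of 6 heavy atoms (3 carbon, 1 nitrogen, 1 oxygen, 1 iodine; no ring), on a saturated chain carbon, six bonds along the chain from a nitrogen on an aromatic ring. The two known steps bear on it: a number 20 percentage points higher from compound 2 to compound 3 (beyond the scatter) and a number 27 percentage points lower from compound 1 to compound 3 (beyond the scatter) both show that a longer group along this chain goes with more inhibition, while a number 47 percentage points lower from compound 1 to compound 2 (beyond the scatter) shows the largest shift. Since the entering group is larger by the count given, a modest rise in this assay is expected for compound 4, estimated as a number 15 percentage points higher from compound 3 to compound 4 (beyond the scatter), though the entering group is not the same kind of end as before. Compound 4 is therefore expected at 35%, within 10% to 60%.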

Compound 4, a percentage reported as inhibition, at one concentration (the size of the read-out at that concentration, not a potency): 0%
For compound 4 the middle estimate is 35 percentage points above the measured one; measured number outside the range, below it.
By their numbers in this assay, from the lowest: compounds 2 and 4 (each within the scatter of the next); then compound 3; then compound 1.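

Within this assay, putting the group of 8 heavy atoms in place of (((iodomethyl)carbonyl)amino)methyl at this chain position lowers inhibition (a number 20 percentage points lower from compound 3 to compound 4 (beyond the scatter)), so a larger group here does not by itself give more inhibition, and compound 4 goes against the rise seen with chain length from compound 2 through compound 3 to compound 1. The other two steps place it level with the short-chain compound and far from the best one (no change at the digits printed from compound 2 to compound 4 (within the scatter); a number 47 percentage points lower from compound 1 to compound 4 (beyond the scatter)). No supporting measurement accounts for this loss. On these data alone, whether a longer chain ending in ((iodomethyl)carbonyl)amino would exceed compound 1 remains open, as does the effect of an amine or a carboxylic acid at the chain end.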